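A chloro-to-methoxy swap on the hydroxyphenyl end

A few compounds are considered here, and "the series" means these few. Any claim that something is new, unique, unknown or untested is made for them only; others in the source may bear on it.

In a functional assay on SW-620 cells (Homo sapiens) for cytotoxicity, read by MTT assay, with a stated time of 72 h (on this read-out lower numbers stand for stronger inhibition and higher numbers for weaker inhibition), compound 1 (`COc1cccc(/C=C2\CCC/C(=C\c3ccc(Br)cc3)C2=O)c1OC`) gives 11100 nM and compound 2 (`COc1cccc(/C=C2\CCC/C(=C\c3ccc(O)c(Cl)c3)C2=O)c1OC`) gives 16800 nM so the two stand within the scatter of each other. Compound 3 (`COc1cc(/C=C2\CCC/C(=C\c3cccc(OC)c3OC)C2=O)ccc1O`) has methoxy in place of chloro on an aromatic carbon and so turns 3-chloro-4-hydroxyphenyl into 4-hydroxy-3-methoxyphenyl. Going by the values given here, the one measured step (a 1.5-fold higher number from compound 1 to compound 2 (0.18 log units; within the scatter)) changed that same end of the molecule and stayed small. No step beyond the scatter is therefore expected in this assay and the expected change is a 1.3-fold lower number from compound 2 to compound 3 (0.11 log units; within the scatter) at most a modest one. The estimated value for compound 3 is 13000 nM and it is expected to lie between 6000 nM and 28000 nM.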

Compound 3, half-maximal inhibitory concentration: 8600 nM
For compound 3 the middle estimate is 1.5-fold (0.18 log units) above the measured one; low and high end bracket the measured number.
By their numbers in this assay, from the lowest: compounds 3, 1 and 2 (each within the scatter of the next).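

In this assay, methoxy in place of chloro on this aromatic carbon, ortho to a hydroxy group, gives a 2.0-fold lower number from compound 2 to compound 3 (0.29 log units; within the scatter), so the swap to the larger group with a hydrogen-bond acceptor produces no step beyond the scatter. Setting the 4-hydroxy-3-methoxyphenyl end against the 4-bromophenyl end gives a 1.3-fold lower number from compound 1 to compound 3 (0.11 log units; within the scatter), so all three ends shown on the shared core lie within the scatter of one another. No measurement here offers an explanation for this result. On these data alone, whether an amine or a carboxylic acid at this position would stay within that range remains open.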